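A few compounds are considered here, and "the series" means these few. Any claim that something is new, unique, unknown or untested is made for them only; others in the source may bear on it.

Measured compounds in an assay on isolated protein for binding affinity to leukotriene B4 receptor 1 (Homo sapiens), tested at 1 uM; on this read-out lower numbers stand for less inhibition and higher numbers for more inhibition at the one concentration tested (going by the name of the read-out):
compound 1 `CCCCCc1cc(C(C)=O)c(O)cc1OCCCCC#N` gives 14%
compound 2 `CCc1cc(C(C)=O)c(O)cc1OCCCCCCC#N` gives 73%
compound 3 `CSCc1cc(C(C)=O)c(O)cc1OCCCCCCC#N` gives 64%

Compound 1 stands lowest of the three numbers in this assay; compound 3 is nearest to it and compound 2 furthest, both gaps beyond the scatter. Compounds 2 and 3 carry a longer nitrile-bearing chain than compound 1 and so differ from compound 1 in two places at once; their gap to compound 1 cannot be read as the effect of a single change.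

Compound 4 `C=CCc1cc(C(C)=O)c(O)cc1OCCCCC#N` is not yet measured. Its difference from compound 1 is vinyl in place of butyl on a saturated chain carbon bound to an aromatic carbon. Among the compounds with values here, the only measured step that changes one place is a number 9 percentage points lower from compound 2 to compound 3 (within the scatter), a swap on a saturated chain carbon bound to an aromatic carbon that left the number within the scatter. That step concerns a different pair of groups, so it bears on the present change only loosely; it gives no sign that a change at this place moves the number far. Within the data shown here, the butyl-to-vinyl change has no direct precedent here, and the expectation is therefore a step near zero: compound 4 is expected to show a number 6 percentage points higher from compound 1 to compound 4 (within the scatter), not beyond the scatter. Compound 4 is estimated at 20%, with a range from 5% to 45%.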

Compound 4, a percentage reported as inhibition, at one concentration (the size of the read-out at that concentration, not a potency): 57%
Compound 4: middle estimate off by 37 percentage points, on the low side; measured number outside the range, above it.
By their numbers in this assay, from the lowest: compound 1; then compounds 4, 3 and 2 (each within the scatter of the next, the first and the last beyond it).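

Working notes on the series: in this assay, vinyl in place of butyl on a saturated chain carbon bound to an aromatic carbon gives a number 43 percentage points higher from compound 1 to compound 4 (beyond the scatter) and thus shows that a change at this place can move the number strongly, at least with the nitrile-bearing chain of compound 1. The earlier single-place step at this carbon, a number 9 percentage points lower from compound 2 to compound 3 (within the scatter) and involving another pair of groups on a longer nitrile-bearing chain, gave no sign of this, while the new change both shortens the group from pentyl to allyl and brings in a double bond outside aromatic rings. No measurement here explains the size of the step.

Open, from the compounds shown here alone, is whether the shorter group or the double bond carries the step: ethyl in place of vinyl at the same carbon, with the nitrile-bearing chain of compound 1 unchanged, would separate the two. Also open, going by these compounds, are the effect of the longer nitrile-bearing chain alone, with the substituent held constant, and whether a carboxylic acid in place of the nitrile keeps the number of compound 4.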